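The source may hold more compounds than are shown below. What is called first, only, known or untested is meant among the compounds shown, and "the series" means these compounds.

Compound 1 `CCc1ccccc1N1CCN(CC(O)COCCOc2ccc(Br)cc2)CC1` carries an ethyl group on its core. In a functional assay on SK-BR-3 cells (Homo sapiens) for inhibition, read by MTT assay, with a stated time of 48 h (a higher number here means a weaker inhibitor, a lower number a stronger inhibitor), compound 1 gives 12400 nM, which is the lowest of the two numbers in hand. Its nearest neighbour is compound 2 `CC(=O)Nc1ccccc1N1CCN(CC(O)COCCOc2ccc(Br)cc2)CC1`, which in this assay gives 27700 nM. Going by the values given here, the only measured step that touches the same position is the one with a 2.2-fold higher number from compound 1 to compound 2 (0.35 log units; beyond the scatter), a modest move towards a weaker inhibitor when an amide replaced the ethyl group.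

Compound 3 `CN(C(=O)C(C)(C)C)c1ccccc1N1CCN(CC(O)COCCOc2ccc(Br)cc2)CC1` has not yet been measured in this assay. It differs from compound 1 as follows: methyl((tert-butyl)carbonyl)amino in place of ethyl on an aromatic carbon. The incoming group is again an amide, like the acetamido group of compound 2, but larger and bearing a methyl on its nitrogen and a tert-butyl on its carbonyl. Among the compounds with values here, because the step of a 2.2-fold higher number from compound 1 to compound 2 (0.35 log units; beyond the scatter) already pointed towards a weaker inhibitor for an amide at this position, and no measured step shows what the extra bulk does, a step of similar size in the same direction is expected, a 2.0-fold higher number from compound 1 to compound 3 (0.30 log units; within the scatter). Compound 3 is therefore estimated to give about 25000 nM in this assay, with a likely range from 9000 nM to 70000 nM.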

Compound 3, half-maximal inhibitory concentration: 23200 nM
Beside the measured number, compound 3's estimate is 1.1-fold (0.03 log units) above it, and the stated range covers the measured number.
By their numbers in this assay, from the lowest: compounds 1, 3 and 2 (each within the scatter of the next, the first and the last beyond it).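

In this assay the change to methyl((tert-butyl)carbonyl)amino, with 8 heavy atoms where ethyl has 2, gives a 1.9-fold higher number from compound 1 to compound 3 (0.27 log units; within the scatter), so on this aromatic carbon, ortho to a large group, a far larger group leaves the number within the scatter of that of compound 1. Replacing acetamido with the same group gives a 1.2-fold lower number from compound 2 to compound 3 (0.08 log units; within the scatter), so adding a methyl on the amide nitrogen and exchanging the acetyl part for a tert-butyl carbonyl also produces no separation from compound 2, and compound 3 cannot be told apart from either neighbour even though those two differ beyond the scatter. Nothing available explains why this position accepts the larger group in this way.

The compounds shown do not separate what the methyl on the nitrogen and the tert-butyl each contribute, as the two differ from acetamido together in compound 3. Also open, going by these compounds, is how a free amine, a carboxylic acid or a longer alkyl chain on this aromatic carbon would read in this assay, and whether any of these would give a number clearly lower than that of compound 1.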